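Replacing 4-Methoxyphenyl with 1-Benzothiophen-2-yl on the Shared Core

The source may report more compounds than this note shows. Statements on the series, on what has been measured and on what is new or still open speak of the compounds shown alone.

Measured so far:
Compound 1 `CCOC(=O)c1cnc(C(F)(F)F)nc1NN1C(=O)C=C(C)C1=O` gives 1000 nM
Compound 2 `CCOC(=O)c1cnc(-c2ccc(OC)cc2)nc1NN1C(=O)C=C(C)C1=O` gives 900 nM
Compound 3 `CCOC(=O)c1cnc(-c2cccc(Br)c2)nc1NN1C(=O)C=C(C)C1=O` gives 700 nM

All three compounds were tested in a functional assay on Jurkat cells for inhibition of nuclear factor NF-kappa-B complex (Homo sapiens) (on this read-out higher numbers stand for weaker inhibition and lower numbers for stronger inhibition), and their numbers lie close together. Compound 2 has the second highest of the three numbers: its nearest neighbour is compound 1, the furthest is compound 3, and both gaps fall within the scatter of the assay. The measured steps are a 1.1-fold lower number from compound 1 to compound 2 (0.05 log units; within the scatter), a 1.4-fold lower number from compound 1 to compound 3 (0.15 log units; within the scatter) and a 1.3-fold lower number from compound 2 to compound 3 (0.11 log units; within the scatter); none of them reaches beyond the scatter.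

Compound 4 `CCOC(=O)c1cnc(-c2cc3ccccc3s2)nc1NN1C(=O)C=C(C)C1=O` is the next compound to be measured. It differs from compound 2 as follows: 1-benzothiophen-2-yl in place of 4-methoxyphenyl on an aromatic carbon. All three measured steps bear on this change, since each of them also swaps the group at this same position on the shared core, and each of them left the number essentially unchanged. On that basis no step beyond the scatter is expected for compound 4 either, in either direction.

The step from compound 2 to compound 4 is therefore estimated as a 1.1-fold lower number from compound 2 to compound 4 (0.05 log units; within the scatter). For compound 4 the expected value in this assay is 800 nM, with a likely range from 350 nM to 1800 nM.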

Compound 4, half-maximal inhibitory concentration: 4000 nM
Estimate against measurement, compound 4: 5.0-fold (0.70 log units) below; the whole stated range lies below it.
By their numbers in this assay, from the lowest: compounds 3, 2 and 1 (each within the scatter of the next); then compound 4.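

Up to this point, the aromatic carbon between two ring nitrogen atoms looked undemanding in this assay, since trifluoromethyl, 4-methoxyphenyl and 3-bromophenyl could replace one another with no step beyond the scatter. 1-Benzothiophen-2-yl is the first group in this set to shift the result, and it shifts it towards weaker inhibition against all three earlier groups: a 4.4-fold higher number from compound 2 to compound 4 (0.65 log units; beyond the scatter), a 5.7-fold higher number from compound 3 to compound 4 (0.76 log units; beyond the scatter) and a 4.0-fold higher number from compound 1 to compound 4 (0.60 log units; beyond the scatter). The position is therefore not indifferent to what it carries, even though no measurement at hand explains this particular change.

The compounds shown do not separate the contribution of the sulfur-containing five-membered ring from that of the attached six-membered ring; a thiophen-2-yl group and a naphthalen-2-yl group on the same carbon would help to tell these apart. From the compounds shown here alone, it also remains open whether the shift belongs to this group alone or extends to other groups at this position, such as an amine or a carboxylic acid, or to a version of the shared core with something other than the ethoxycarbonyl group.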